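The source may hold more compounds than are shown below. What is called first, only, known or untested is meant among the compounds shown, and "the series" means these compounds.

Values in a functional assay on PC-3 cells (Homo sapiens) for cytotoxicity, read by sulforhodamine B assay, with a stated time of 48 h; a higher number here means a weaker inhibitor, a lower number a stronger inhibitor:
compound 1 `C[C@H]1CC[C@@H]2[C@@H](OC(=O)[C@]23CC(c2ccccc2)=NO3)[C@]2(C)C(=O)C=C[C@@]12O`: 46000 nM
compound 2 `Cc1ccccc1C1=NO[C@]2(C1)C(=O)O[C@@H]1[C@H]2CC[C@H](C)[C@]2(O)C=CC(=O)[C@@]12C`: 10000 nM
compound 3 `Cc1ccc(C2=NO[C@]3(C2)C(=O)O[C@@H]2[C@H]3CC[C@H](C)[C@]3(O)C=CC(=O)[C@@]23C)cc1`: 14000 nM

Compound 3 stands clearly apart only from compound 1. The step of a 3.3-fold lower number from compound 1 to compound 3 (0.52 log units; beyond the scatter) is modest, whereas the step of a 1.4-fold higher number from compound 2 to compound 3 (0.15 log units; within the scatter) stays within the scatter.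

Next comes compound 4 `C[C@H]1CC[C@@H]2[C@@H](OC(=O)[C@]23CC(c2ccc(C#N)cc2)=NO3)[C@]2(C)C(=O)C=C[C@@]12O`, which carries cyano in place of methyl on an aromatic carbon, para to a large group: cyano in place of methyl on an aromatic carbon. For the measured compounds named here, no measured step introduces cyano, so the only guides are the two methyl steps, a 4.6-fold lower number from compound 1 to compound 2 (0.66 log units; beyond the scatter) and a 3.3-fold lower number from compound 1 to compound 3 (0.52 log units; beyond the scatter), both modest. Compound 4 gives up the methyl behind the second of these, so some drift back towards compound 1 at 46000 nM is possible, though nothing measured fixes its extent. The estimated change is a 1.4-fold higher number from compound 3 to compound 4 (0.15 log units; within the scatter), a small move towards a higher number that is not expected to leave the scatter. For compound 4 the expected value is 20000 nM, with an estimated range of 7000 nM to 55000 nM.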

Compound 4, half-maximal inhibitory concentration: 32000 nM
For compound 4 the middle estimate is 1.6-fold (0.20 log units) below the measured one; the measured number falls inside the stated range.
By their numbers in this assay, from the lowest: compounds 2 and 3 (each within the scatter of the next); then compounds 4 and 1 (each within the scatter of the next).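

Cyano in place of methyl on an aromatic carbon, para to a large group, gives a 2.3-fold higher number from compound 3 to compound 4 (0.36 log units; beyond the scatter) in this assay, so methyl and cyano are not interchangeable at this position, which the methyl compounds alone could not show. Cyano in place of hydrogen at that carbon gives only a 1.4-fold lower number from compound 1 to compound 4 (0.16 log units; within the scatter) and so does not reproduce the gain seen with methyl, while a 3.2-fold higher number from compound 2 to compound 4 (0.51 log units; beyond the scatter) sets the 4-cyanophenyl compound apart from the 2-methylphenyl compound as well. Nothing available explains why the two groups differ here.

The compounds shown leave open how other groups on this carbon would read, such as an amine, a carboxylic acid or a longer chain. Also open, on these data alone, is how cyano would read in the place of the methyl of compound 2.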